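This account rests on a few compounds, and the source may have more. Where it says the series, first, only, none or still open, it means among the compounds named here.

Measured so far:
Compound 1 `O=C(/C=C\Nc1ccc(O)cc1)c1cn(-c2ccccc2)nc1-c1ccccc1`: 5000 nM
Compound 2 `COc1cc(N/C=C\C(=O)c2cn(-c3ccccc3)nc2-c2ccccc2)cc(OC)c1OC`: 9800 nM
Compound 3 `O=C(/C=C\Nc1ccc(O)cc1)c1cn(-c2ccccc2)nc1-c1ccc(F)cc1`: 1900 nM

All three were tested in a functional assay on HT-29 cells (Homo sapiens) for antiproliferative activity, read by MTT assay, with a stated time of 48 h; a lower number here means a stronger inhibitor, a higher number a weaker inhibitor. Compound 1 and compound 2 share a core but differ in more than one place; the difference between the two cores is not broken down here. Compound 3 comes from compound 1 by a single change, (fluoro in place of hydrogen on an aromatic carbon), and this gave a 2.6-fold lower number from compound 1 to compound 3 (0.42 log units; beyond the scatter). Compound 4 `COc1cc(N/C=C\C(=O)c2cn(-c3ccccc3)nc2-c2ccc(F)cc2)cc(OC)c1OC` is not yet measured; it comes from compound 2 by the same change, (fluoro in place of hydrogen on an aromatic carbon), at a place described in the same words. For the measured compounds named here, an expected step of about a 2.5-fold lower number from compound 2 to compound 4 (0.39 log units; beyond the scatter) rests on a 2.6-fold lower number from compound 1 to compound 3 (0.42 log units; beyond the scatter), which is the only example of this change with numbers on both sides. For compound 4 the estimated value in this assay is 4000 nM, expected to fall between 1500 nM and 10000 nM.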

Compound 4, half-maximal inhibitory concentration: 7770 nM
For compound 4 the middle estimate is 1.9-fold (0.29 log units) below the measured one; the range from low to high includes it.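

In this assay, fluoro in place of hydrogen on an aromatic carbon gave a 1.3-fold lower number from compound 2 to compound 4 (0.10 log units; within the scatter), a step too small to tell apart from repeat measurements. Set beside the earlier example, the two steps cannot be told apart either: the same change on two cores in this assay, a 2.6-fold lower number (0.42 log units; beyond the scatter) from compound 1 to compound 3 and a 1.3-fold lower number (0.10 log units; within the scatter) from compound 2 to compound 4, 2.1-fold (0.32 log units) apart, within the scatter of two such steps. So the result does not contradict carrying this change from one core to the other, but it does not show that the gain seen on the core of compound 1 carries over, and two pairs cannot settle the matter.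

The compounds shown leave open how a chloro, a trifluoromethyl or an amine would behave at the same place. They also leave open how fluoro would behave on any further core.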